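Replacing Fluoro with a Diethylamino Acetamide Group

The source may hold more compounds than are shown below. What is called first, only, known or untested is meant among the compounds shown, and "the series" means these compounds.

In an ADME assay on MDBK cells (Bos taurus) for cytotoxicity, read by MTT assay, with a stated time of 96 h (on this read-out lower numbers stand for higher toxicity in this test and higher numbers for lower toxicity in this test), compound 1 `Fc1ccc(-c2nc3cc(C(F)(F)F)ccc3[nH]2)cc1` gives 19000 nM, the lower of the two numbers obtained in this set. Compound 2 `CN1CCN(CC(=O)Nc2ccc(-c3nc4cc(Cl)c(Cl)cc4[nH]3)cc2)CC1` gives 90000 nM, and its gap from compound 1 lies beyond the usual scatter. Compound 3 `CCC(=O)Nc1ccc(-c2nc3cc(C(F)(F)F)ccc3n2C)cc1` gives > 100000 nM, which is a limit of the test rather than a number (the limit of > 100000 nM in this assay, at which 1 of the 3 values shown sits). Compound 4 `CCN(CC)CC(=O)Nc1ccc(-c2nc3cc(C(F)(F)F)ccc3[nH]2)cc1` has not yet been measured in this assay. It differs from compound 1 in one place: (((diethylamino)methyl)carbonyl)amino in place of fluoro on an aromatic carbon. Among the measured compounds shown here, no measured pair shows this change on its own. The estimate leans on compound 2 with 90000 nM as the closest measured neighbour. The number for compound 4 is expected to rise by a 3.2-fold higher number from compound 1 to compound 4 (0.50 log units; beyond the scatter). Compound 4 is therefore estimated at 60000 nM, within a range from 20000 nM to 150000 nM.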

Compound 4, half-maximal cytotoxic concentration: 13000 nM
For compound 4 the middle estimate is 4.6-fold (0.66 log units) above the measured one; the measured number lies below the stated range.
By their numbers in this assay, from the lowest: compounds 4 and 1 (each within the scatter of the next); then compound 2. At a limit, above all of these: compound 3.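

In this assay, putting (((diethylamino)methyl)carbonyl)amino in place of fluoro gives a 1.5-fold lower number from compound 1 to compound 4 (0.16 log units; within the scatter). Among the compounds shown here, this is the only single-place step in the set, and it shows that this aromatic carbon, para to a large group, takes a chain of 9 heavy atoms instead of 1 with no change in the read-out beyond the scatter. Nothing measured here offers an explanation for this result.

From the compounds shown here alone, it remains open whether a free amine, a carboxylic acid or a longer chain on the same carbon would also leave the number within the scatter of compound 1.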